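Ketone aryl variation on the shared trimethoxyphenyl core

The source may hold more compounds than are shown below. What is called first, only, known or untested is meant among the compounds shown, and "the series" means these compounds.

Measured so far:
compound 1 `COc1cc(-c2cc(/C=C/C(=O)c3ccc(N)cc3)[nH]n2)cc(OC)c1OC` — 6790 nM
compound 2 `COc1cc(-c2cc(/C=C/C(=O)c3ccc(Cl)c(Cl)c3)[nH]n2)cc(OC)c1OC` — a limit of the assay, > 100000 nM
compound 3 `COc1ccc(C(=O)/C=C/c2cc(-c3cc(OC)c(OC)c(OC)c3)n[nH]2)cc1OC` — 5240 nM

In a functional assay on NCI-H23 cells (Homo sapiens) for inhibition, read by sulforhodamine B assay, with a stated time of 48 h (a higher number here means a weaker inhibitor of growth, a lower number a stronger inhibitor of growth), compound 3 gives 5240 nM, the lowest of the two numbers shown, with compound 1 closest: a 1.3-fold lower number from compound 1 to compound 3 (0.11 log units; within the scatter). For compound 2 the value is a limit of the assay only (the limit of > 100000 nM in this assay, at which 1 of the 3 values shown sits). The steps to and from it are large: an at least 14-fold higher number from compound 1 to compound 2 (1.16 log units; beyond the scatter) and an at least 19-fold lower number from compound 2 to compound 3 (1.28 log units; beyond the scatter).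

Compound 4 `COc1ccc(C(=O)/C=C/c2cc(-c3cc(OC)c(OC)c(OC)c3)n[nH]2)cc1` is not yet measured. It differs from compound 3 by hydrogen in place of methoxy on an aromatic carbon. Going by the values given here, no measured step removes a methoxy; the nearest guide is a 1.3-fold lower number from compound 1 to compound 3 (0.11 log units; within the scatter), a small step between two substituted aryl groups on the carbonyl carbon, whereas the 3,4-dichlorophenyl case shows that a large step is possible. A step within the scatter is expected: a 1.1-fold higher number from compound 3 to compound 4 (0.06 log units; within the scatter). Compound 4 is estimated at 6000 nM, with a range from 2500 nM to 16000 nM.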

Compound 4, concentration for total growth inhibition: 12200 nM
The estimate for compound 4 lay 2.0-fold (0.31 log units) below the measured number, and the stated range covers the measured number.
By their numbers in this assay, from the lowest: compounds 3, 1 and 4 (each within the scatter of the next, the first and the last beyond it). At a limit, above all of these: compound 2.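

In this assay, the change from 3,4-dimethoxyphenyl to 4-methoxyphenyl gives a real, though modest, shift: a 2.3-fold higher number from compound 3 to compound 4 (0.37 log units; beyond the scatter). With one group on this aryl ring, methoxy and amino are not separated: a 1.8-fold higher number from compound 1 to compound 4 (0.25 log units; within the scatter). Against the 3,4-dichlorophenyl group the step is an at least 8.1-fold lower number from compound 2 to compound 4 (0.91 log units; beyond the scatter), and it rests on a limit of the assay.

Open, on these data alone, is how an unsubstituted phenyl, or a hydroxy or dimethylamino group in place of the methoxy, would read here. Also open, as far as these compounds go, is whether a single chlorine would account for the dichlorophenyl result.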